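4-fluorophenyl in place of pyridin-4-yl on compound 2

A few compounds are considered here, and "the series" means these few. Any claim that something is new, unique, unknown or untested is made for them only; others in the source may bear on it.

In a functional assay on PC-3 cells (Homo sapiens) for antiproliferative activity, read by MTT assay, with a stated time of 24 h (on this read-out lower numbers stand for stronger inhibition and higher numbers for weaker inhibition), compound 1 (`c1ccc(-c2noc(-c3ccncc3)n2)cc1`) reads > 1000000 nM as a limit of the assay and not as a number. In this assay compound 2 (`COc1ccc(-c2noc(-c3ccncc3)n2)cc1OC1CCCC1`) reads > 1000000 nM as a limit as well. Compound 3 (`COc1ccc(-c2noc(Cc3c[nH]c4ccccc34)n2)cc1OC1CCCC1`) reads > 1000000 nM as a limit too. For the measured compounds named here, compound 2 therefore has no number of its own, and the series so far offers only the limit of > 1000000 nM in this assay, at which 3 of the 3 values shown sit, with no step between measured compounds to give a scale.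

Compound 4 (`COc1ccc(-c2noc(-c3ccc(F)cc3)n2)cc1OC1CCCC1`) differs from compound 2 in one place, on an aromatic carbon of a five-membered aromatic ring with 2 nitrogen and 1 oxygen, where 4-fluorophenyl stands in place of pyridin-4-yl (4-fluorophenyl in place of pyridin-4-yl on an aromatic carbon). The expectation starts from compound 2 at > 1000000 nM as a limit. The estimated step of an at least 1.4-fold lower number from compound 2 to compound 4 (0.15 log units; that floor lies within the scatter) is small, in the direction of stronger inhibition if any shows, and another reading at the limit is the likeliest outcome. In this assay the expected value for compound 4 is 700000 nM within an estimated range from 100000 nM to 1000000 nM as matters stand.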

Compound 4, half-maximal inhibitory concentration: > 1000000 nM
Compound 4 ended at the assay's limit (the forecaster's own chance of this, stated with the estimate: 65%); middle value at least 1.4-fold (0.15 log units) from the limit.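

The step from compound 2 to compound 4 cannot be read: both compounds give only a limit in this assay, not a number. The compounds shown leave open whether any change on the shared core gives a readable antiproliferative value, and how large any step would be, with every reading so far at one value: the limit of > 1000000 nM in this assay, at which 4 of the 4 values shown sit.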